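The compounds below may be only part of what the source reports. "The series", "measured", "known", "first", "only" and "open" are said of these compounds alone.

Measured in a functional assay on A549 cells (Homo sapiens) for inhibition, read by sulforhodamine B assay, with a stated time of 72 h; on this read-out higher numbers stand for weaker inhibition of growth and lower numbers for stronger inhibition of growth:
- compound 1 `CNC(=O)/C=C/c1ccncc1-c1ccc2cc[nH]c2c1`: 7840 nM
- compound 2 `O=C(O)/C=C/c1ccncc1-c1ccc2ccccc2c1`: > 10000 nM (a limit, not a number)

Compound 2 stands only at a limit of this assay, and (the limit of > 10000 nM in this assay, at which 1 of the 2 values shown sits).

Compound 3 `O=C(/C=C/c1ccncc1-c1ccc2ccccc2c1)NC1CC1` has cyclopropylamino in place of hydroxy on a carbonyl carbon, carboxy to cyclopropylcarbamoyl: cyclopropylamino in place of hydroxy on a carbonyl carbon.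

Among the measured compounds shown here, no measured step in this assay guides this change. For the measured compounds named here, the only true number, compound 1 at 7840 nM, anchors the expectation. A modest move toward stronger inhibition of growth is expected, an at least 1.5-fold lower number from compound 2 to compound 3 (0.18 log units; that floor lies within the scatter). For compound 3 the estimated value is 6500 nM, with an expected range of 2000 nM to 15000 nM.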

Compound 3, concentration for 50% growth inhibition: 5840 nM
The estimate for compound 3 lay 1.1-fold (0.05 log units) above the measured number; the range from low to high includes it.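

Cyclopropylamino in place of hydroxy on a carbonyl carbon gives the first step that can be read at this position in this assay (an at least 1.7-fold lower number from compound 2 to compound 3 (0.23 log units; that floor lies within the scatter)). Compound 3 brings a true number to this core, 5840 nM. Compound 2 holds a limit, not a number, and the step therefore has only a floor: the limit of > 10000 nM in this assay, at which 1 of the 3 values shown sits.

From the compounds shown here alone, the true size of the step stays open. Also open, going by these compounds, is how a longer alkyl chain or a morpholine in place of cyclopropylamino on this carbonyl carbon would read.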